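Replacing the Hydroxy Group of Compound 3

The source may hold more compounds than are shown below. What is called first, only, known or untested is meant among the compounds shown, and "the series" means these compounds.

Of the compounds shown here, three sharing one core have been tested in a functional assay on MC-38 cells (Mus musculus) for antiproliferative activity, read by CCK-8 assay, with a stated time of 48 h; on this read-out lower numbers stand for stronger inhibition and higher numbers for weaker inhibition. Compound 1 (`COc1ccc(/C=C\c2cc(OC)c(OC)c(OC)c2)cc1OCc1ccc(CN2CCCC[C@@H]2C(=O)O)cc1`) gives only a limit, > 10000 nM, and not a true number. Compound 2 (`COc1ccc(/C=C\c2cc(OC)c(OC)c(OC)c2)cc1OCc1ccc(CN2CC[C@H](C(=O)O)C2)cc1`) also gives only a limit, > 10000 nM. Within the data shown here, compound 3 (`COc1ccc(/C=C\c2cc(OC)c(OC)c(OC)c2)cc1OCc1ccc(CO)cc1`) gives 5700 nM, the only actual number so far, so it has no exact value to be ranked against.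

The next compound is compound 4 (`COc1ccc(/C=C\c2cc(OC)c(OC)c(OC)c2)cc1OCc1ccc(CN2CCCCC2C(=O)NCCN)cc1`), in which 2-((2-aminoethyl)carbamoyl)piperidin-1-yl takes the place of hydroxy on a saturated chain carbon bound to an aromatic carbon: 2-((2-aminoethyl)carbamoyl)piperidin-1-yl in place of hydroxy on a saturated chain carbon bound to an aromatic carbon.

Among the measured compounds shown here, two measured steps bear on this change, an at least 1.7-fold lower number from compound 1 to compound 3 (0.24 log units; that floor lies within the scatter) and an at least 1.7-fold lower number from compound 2 to compound 3 (0.24 log units; that floor lies within the scatter). Both run in the opposite direction, putting hydroxy in place of a carboxy-bearing group, and both floors lie within the scatter. Going by these compounds, they rest on (the limit of > 10000 nM in this assay, at which 2 of the 3 values shown sit), so their true sizes remain unknown. Neither entering group matches the new one, which has no carboxy group, so these steps offer only a weak guide.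

No clear shift in this assay is therefore expected, and the expected result is a 1.1-fold lower number from compound 3 to compound 4 (0.06 log units; within the scatter). For compound 4 the estimated value is 5000 nM, with an expected range of 1500 nM to 10000 nM.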

Compound 4, half-maximal inhibitory concentration: > 10000 nM
Compound 4 gave a limit, no number; the forecaster's own chance of this, stated with the estimate: 30%; middle value at least 2.0-fold (0.30 log units) away from the limit.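

In this assay, compound 4 gives > 10000 nM, which is a limit and not a number. Among these compounds, until now, the only groups tried in place of hydroxy on this saturated chain carbon carried a carboxy group, whereas 2-((2-aminoethyl)carbamoyl)piperidin-1-yl has none, and the step still reads as an at least 1.7-fold higher number from compound 3 to compound 4 (0.24 log units; that floor lies within the scatter), so this result does not establish a real loss. What it adds is that a number has not appeared at this place for any of the three ring-bearing groups, with or without a carboxy group, and the comparisons are therefore blunt, with the steps from compound 1 and from compound 2 to compound 4 unreadable, each joining two limits: the limit of > 10000 nM in this assay, at which 3 of the 4 values shown sit.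

The compounds shown leave open how far above the limit the true values of these three compounds lie, and so whether the amide with its 2-aminoethyl chain differs at all from the carboxylic acids. A small group on the same carbon, such as a methoxy group or a simple dimethylamino group, could show whether any replacement of hydroxy gives a readable number in this assay.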